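The source may hold more compounds than are shown below. What is called first, only, known or untested is meant among the compounds shown, and "the series" means these compounds.

Measured compounds:
Compound 1 `NC(=O)CC[C@H](NC(=O)CN(c1ncnc2c1ncn2C1CCCCO1)C1CC1)C(=O)OCc1ccccc1`: in a functional assay on the whole organism (Tail, strain ICR) with Mus musculus as the target, in the tail flick test, with a stated time of 90 min, at a dose of 25 umol/kg by the oral route (a higher number here means a stronger effect of the compound at the dose given, a lower number a weaker effect), compound 1 gives 37.8%.
Compound 2 `NC(=O)C[C@H](NC(=O)CN(c1nc(Cl)nc2[nH]cnc12)C1CC1)C(=O)OCc1ccccc1`: in this assay compound 2 gives 32.3%.
Compound 3 `NC(=O)CC[C@H](NC(=O)CN(c1nc(Cl)nc2[nH]cnc12)C1CC1)C(=O)OCc1ccccc1`: in this assay compound 3 gives 42.8%.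

Compound 1 stands second highest of these three numbers; its nearest neighbour is compound 3 and its furthest is compound 2, and both gaps lie within the scatter. Compound 4 `CC(C)(C)OC(=O)NCCCC[C@H](NC(=O)CN(c1ncnc2c1ncn2C1CCCCO1)C1CC1)C(=O)OCc1ccccc1` differs from compound 1 in one place: 2-((tert-butoxycarbonyl)amino)ethyl in place of carbamoyl on a saturated chain carbon, three bonds along the chain from an amide-type nitrogen and a carbonyl carbon. Among the measured compounds shown here, the only measured step at a related position, a number 10.5 percentage points higher from compound 2 to compound 3 (beyond the scatter), put carbamoylmethyl in place of carbamoyl and rose modestly. For the measured compounds named here, the present change is larger and no measured pair reproduces it, so the expected step of a number 2.2 percentage points higher from compound 1 to compound 4 (within the scatter) is none beyond the scatter. Compound 4 is therefore estimated at 40%, with a range from 22% to 58%.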

Compound 4, a percentage reported as activity, at one dose (the size of the read-out at that dose, not a potency): 32.9%
Beside the measured number, compound 4's estimate is 7.1 percentage points above it; measured number inside the range.
By their numbers in this assay, from the lowest: compounds 2, 4, 1 and 3 (each within the scatter of the next, the first and the last beyond it).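

Replacing carbamoyl on this saturated chain carbon with 2-((tert-butoxycarbonyl)amino)ethyl, which has 10 heavy atoms against 3, gives a number 4.9 percentage points lower from compound 1 to compound 4 (within the scatter) in this assay. The read-out at this dose therefore tolerates a much larger, ring-free group at this place on the core of compound 1. No available data explain this result. The compounds shown leave open whether a free primary amine or a carboxylic acid at the end of this chain would stay within the scatter of compound 1. They also leave open whether the same change would behave alike on the core of compound 3.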